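The source may hold more compounds than are shown below. What is called first, only, known or untested is meant among the compounds shown, and "the series" means these compounds.

Three compounds share a core and were tested in a functional assay on NCI-H460 cells (Homo sapiens) for cytotoxicity, read by MTT assay, with a stated time of 72 h; on this read-out lower numbers stand for stronger inhibition and higher numbers for weaker inhibition. Compound 1 `COc1cc2c(Oc3ccc(NC(=O)c4cc(-c5ccc(Cl)c(Cl)c5)nc5ccccc45)cc3F)ccnc2cc1OCCCN1CCCCC1` gives 820 nM in this assay. Compound 2 `COc1cc2c(Oc3ccc(NC(=O)c4cc(-c5ccc(Cl)c(Cl)c5)nc5ccccc45)cc3F)ccnc2cc1OCCCN1CCCC1` differs from it by one change, (pyrrolidin-1-yl in place of piperidin-1-yl on a saturated chain carbon, three bonds along the chain from an oxygen on an aromatic ring), and in this assay compound 2 gives 400 nM. That change made a step of a 2.1-fold lower number from compound 1 to compound 2 (0.31 log units; beyond the scatter). Compound 3 `COc1cc2c(Oc3ccc(NC(=O)c4cc(-c5ccccc5)nc5ccc(F)cc45)cc3F)ccnc2cc1OCCCN1CCCCC1` carries a different core; how its core differs from that of compound 1 is not broken down here. In this assay compound 3 gives 32 nM, the lowest of the three numbers, and its steps to compound 2 and compound 1 both lie beyond the scatter.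

Compound 4 `COc1cc2c(Oc3ccc(NC(=O)c4cc(-c5ccccc5)nc5ccc(F)cc45)cc3F)ccnc2cc1OCCCN1CCCC1` has not yet been measured. Within the data shown here, it differs from compound 3 by pyrrolidin-1-yl in place of piperidin-1-yl on a saturated chain carbon, three bonds along the chain from an oxygen on an aromatic ring, which is the same change as the one from compound 1 to compound 2, made at the same place. Since that change was seen only once, its size on the core of compound 3 rests on a single pair, and the core of compound 3 is not the core of compound 1. Still, the step is expected to be of a similar size, a 1.8-fold lower number from compound 3 to compound 4 (0.25 log units; within the scatter), because the earlier step of a 2.1-fold lower number from compound 1 to compound 2 (0.31 log units; beyond the scatter) went in that direction and beyond the scatter. On that basis compound 4 is expected to give about 18 nM in this assay, with a range estimated from 8 nM to 40 nM.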

Compound 4, half-maximal inhibitory concentration: 90 nM
The estimate for compound 4 lay 5.0-fold (0.70 log units) below the measured number, outside the stated range (above it).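

Pyrrolidin-1-yl in place of piperidin-1-yl gave a 2.8-fold higher number from compound 3 to compound 4 (0.45 log units; beyond the scatter) in this assay, so the change did not keep its direction when carried from the core of compound 1 to the core of compound 3, and the two steps differ by more than the scatter allows: the same change on two cores in this assay, a 2.1-fold lower number (0.31 log units; beyond the scatter) from compound 1 to compound 2 and a 2.8-fold higher number (0.45 log units; beyond the scatter) from compound 3 to compound 4, 5.8-fold (0.76 log units) apart, beyond the scatter of two such steps For these two pairs, then, the step measured on one core does not predict the step on the other, and the choice between the two rings has to be judged on each core separately. Among these compounds, this does not show which feature of the two cores sets the direction of the step, and with only two pairs it gives no rule for any other core.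

The compounds shown leave open how a morpholin-4-yl ring or a dimethylamino group would behave at the end of the same chain on either core, and whether a longer chain would alter the comparison between the two rings. They also leave open what the same change would do on a core that differs from the core of compound 1 in only one place.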